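A Pyridine Swap on an Amide Nitrogen: Toxicity Outlook

The compounds below may be only part of what the source reports. "The series", "measured", "known", "first", "only" and "open" are said of these compounds alone.

Measured compounds in a toxicity assay on HepG2 cells (Homo sapiens) for inhibition, read by CellTiter-Glo, with a stated time of 48 h; on this read-out lower numbers stand for stronger inhibition and higher numbers for weaker inhibition:
- Compound 1 `COc1ccc2nc(C)cc(OCC(=O)Nc3cc(C)c(F)c(C)c3)c2c1`: compound 1 gives a value that is a limit of the assay, > 100000 nM.
- Compound 2 `COc1ccc2nc(C)cc(OCC(=O)Nc3ccc(F)cc3)c2c1`: compound 2 gives 63100 nM.
- Compound 3 `COc1ccc2nc(C)cc(OCC(=O)Nc3ccc(Cl)cc3)c2c1`: compound 3 gives a value that is a limit of the assay, > 100000 nM.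

Compound 3 therefore stands at the limit of > 100000 nM in this assay, at which 2 of the 3 values shown sit, so its position is known only as a limit. The step of an at least 1.5-fold higher number from compound 2 to compound 3 (0.19 log units; that floor lies within the scatter), and the step that the two limits leave unreadable from compound 1 to compound 3, are the two measured steps that reach compound 3. Compound 4 `COc1ccc2nc(C)cc(OCC(=O)Nc3cccnc3)c2c1` differs from compound 3 in one place: pyridin-3-yl in place of 4-chlorophenyl on an amide-type nitrogen. Among the measured compounds shown here, the steps that bear on it are small or unreadable, so in this assay no step beyond the scatter is expected, in either direction. Compound 4 is expected to give about 100000 nM, between 40000 nM and 250000 nM, which means an expected step of a number no higher from compound 3 to compound 4 (the limit leaves the size open).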

Compound 4, half-maximal inhibitory concentration: > 100000 nM
Compound 4: no number, only a limit (the forecaster's own chance of this, stated with the estimate: 60%); the middle value lies on the limit itself.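

In this assay compound 4 gives > 100000 nM, which is a limit. So pyridin-3-yl, the first ring shown here with a hetero atom on the amide-type nitrogen, leaves the reading at a limit too: the limit of > 100000 nM in this assay, at which 3 of the 4 values shown sit.

Among the compounds shown here, the only readable step is an at least 1.5-fold higher number from compound 2 to compound 4 (0.19 log units; that floor lies within the scatter); the steps from compound 1 and compound 3 to compound 4 cannot be read.

As far as these compounds go, the real values of compound 1, compound 3 and compound 4 remain unknown. So does the reading with an amine or a carboxylic acid in place of these rings.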